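From 4-hydroxyphenyl to 2-fluorophenyl on the shared core

The compounds below may be only part of what the source reports. "The series", "measured", "known", "first", "only" and "open" are said of these compounds alone.

In an ADME assay on L929 cells (Mus musculus) for cytotoxicity, read by resazurin assay, with a stated time of 72 h (on this read-out higher numbers stand for weaker inhibition and lower numbers for stronger inhibition), compound 3 (`O=C(/C=C/c1ccc2c(c1)B(O)OC2)c1ccc(O)cc1`) gives > 10 ug/mL as a limit, not a number. Compound 1 (`O=C(/C=C/c1ccc2c(c1)B(O)OC2)c1ccccn1`) gives > 10 ug/mL as a limit too. Compound 2 (`Cc1cccc(C(=O)/C=C/c2ccc3c(c2)B(O)OC3)c1`) gives 8.56 ug/mL as a number. The series therefore sits mostly at the limit of > 10 ug/mL in this assay, at which 2 of the 3 values shown sit, so far.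

Compound 4 (`O=C(/C=C/c1ccc2c(c1)B(O)OC2)c1ccccc1F`) has 2-fluorophenyl in place of 4-hydroxyphenyl on a carbonyl carbon.

The measured steps at this same place are an at least 1.1-fold lower number from compound 1 to compound 2 (0.06 log units; that floor lies within the scatter) and an at least 1.1-fold higher number from compound 2 to compound 3 (0.06 log units; that floor lies within the scatter) and also a step that the two limits leave unreadable from compound 1 to compound 3 without a readable size. Neither readable floor goes beyond the scatter. No step beyond the scatter is therefore expected in this assay and the estimated move is an at least 1.1-fold lower number from compound 3 to compound 4 (0.04 log units; that floor lies within the scatter) in size. For compound 4 the estimated value is 9 ug/mL with an expected range from 4 ug/mL to 15 ug/mL in all.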

Compound 4, half-maximal inhibitory concentration: > 10 ug/mL
Compound 4 ended at the assay's limit; the forecaster's own chance of this, stated with the estimate: 50%; at least 1.1-fold (0.04 log units) between middle value and limit.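

In this assay a third aryl group, 2-fluorophenyl, now joins pyridin-2-yl and 4-hydroxyphenyl at the limit, so the hydrogen-bond donor and acceptor counted for 4-hydroxyphenyl are not needed for a result at the limit here. The steps between limits cannot be read, and an at least 1.1-fold higher number from compound 2 to compound 4 (0.06 log units; that floor lies within the scatter) gives only a floor. The series now reads: the limit of > 10 ug/mL in this assay, at which 3 of the 4 values shown sit.

Going by these compounds, how far compound 1, compound 3 and compound 4 lie past the limit stays open. Also open, on these data alone, is whether an amine or a carboxylic acid on this carbonyl carbon would give a number.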